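From Trifluoromethyl to Methoxy on the Benzyl Ring

The source may hold more compounds than are shown below. What is called first, only, known or untested is meant among the compounds shown, and "the series" means these compounds.

Compound 1 `O=C(NCc1cn(Cc2ccc(F)cc2)nn1)c1cn(-c2ccccc2)nc1-c1ccc(F)cc1` gives 14300 nM in a functional assay on MIA PaCa-2 cells (Homo sapiens) for antiproliferative activity, read by sulforhodamine B assay, with a stated time of 48 h; on this read-out lower numbers stand for stronger inhibition of growth and higher numbers for weaker inhibition of growth.
Compound 2 `O=C(NCc1cn(Cc2ccc(Cl)cc2)nn1)c1cn(-c2ccccc2)nc1-c1ccc(F)cc1` gives 280 nM.
Compound 3 `O=C(NCc1cn(Cc2ccc(C(F)(F)F)cc2)nn1)c1cn(-c2ccccc2)nc1-c1ccc(F)cc1` gives 760 nM.

Among the three measured numbers, compound 3 stands second highest: compound 2 lies closest, with a 2.7-fold higher number from compound 2 to compound 3 (0.43 log units; beyond the scatter), and compound 1 lies furthest, with a 19-fold lower number from compound 1 to compound 3 (1.27 log units; beyond the scatter). The swap from the fluoro of compound 1 to the chloro of compound 2 gave a 51-fold lower number from compound 1 to compound 2 (1.71 log units; beyond the scatter), so this position on the benzyl ring has moved the read-out strongly in every measured step.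

Compound 4 `COc1ccc(Cn2cc(CNC(=O)c3cn(-c4ccccc4)nc3-c3ccc(F)cc3)nn2)cc1` differs from compound 3 in one place: methoxy in place of trifluoromethyl on an aromatic carbon. Among the measured compounds shown here, no measured step covers methoxy at this position, so the measured steps bear on it only indirectly, by showing that substitution here is far from neutral, with large swings between fluoro, chloro and trifluoromethyl. For the measured compounds named here, with no step between a halogen-type group and methoxy available, the direction is open, and the expected step of a 2.6-fold higher number from compound 3 to compound 4 (0.42 log units; beyond the scatter) is taken as a modest rise with a wide range. Compound 4 is therefore estimated at 2000 nM, between 300 nM and 15000 nM.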

Compound 4, concentration for 50% growth inhibition: 3700 nM
The estimate for compound 4 lay 1.9-fold (0.27 log units) below the measured number, and the stated range covers the measured number.
By their numbers in this assay, from the lowest: compound 2; then compound 3; then compound 4; then compound 1.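

Methoxy is the first group at this position to bring in a hydrogen-bond acceptor, and in this assay the replacement of trifluoromethyl gave a 4.9-fold higher number from compound 3 to compound 4 (0.69 log units; beyond the scatter) while the replacement of chloro gave a 13-fold higher number from compound 2 to compound 4 (1.12 log units; beyond the scatter) on the same benzyl ring. Against fluoro, however, methoxy still gave a 3.9-fold lower number from compound 1 to compound 4 (0.59 log units; beyond the scatter), so it places the new compound in the gap that had stood open between compound 3 and compound 1 and does not carry the series past either end. The four groups now fall in a single order from the lowest number to the highest, namely chloro, trifluoromethyl, methoxy and fluoro, with compound 2 the strongest and compound 1 the weakest of the four, and every step between neighbours or more distant members lies beyond the scatter.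

Nothing available accounts for this order, and the numbers alone give no reason why these four groups rank as they do. Still open, on these data alone, is where an amine, a carboxylic acid or a longer chain such as ethoxy would fall in this order at the same position on the benzyl ring.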